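The source may hold more compounds than are shown below. What is called first, only, known or untested is meant among the compounds shown, and "the series" means these compounds.

Measured in a functional assay on MCF7 cells (Homo sapiens) for antiproliferative activity, read by MTT assay, with a stated time of 48 h; a lower number here means a stronger inhibitor, a higher number a weaker inhibitor:
compound 1 `CNCC(=O)Nc1cc(OC)ccc1C(=O)c1cc(OC)c(OC)c(OC)c1` gives 550 nM
compound 2 `CCNCC(=O)Nc1cc(OC)ccc1C(=O)c1cc(OC)c(OC)c(OC)c1` gives 1050 nM
compound 3 `C=C(c1ccc(OC)cc1NC(=O)CNC)c1ccc(OC)c2c1C=CC(C)(C)O2` gives 1010 nM

Compound 4 `C=C(c1ccc(OC)cc1NC(=O)CNCC)c1ccc(OC)c2c1C=CC(C)(C)O2` has not yet been measured in this assay. It differs from compound 3 in one place: methyl in place of hydrogen on a saturated chain carbon bound to an amine nitrogen. The same change is seen between compound 1 and compound 2, (methyl in place of hydrogen on a saturated chain carbon bound to an amine nitrogen), where the step was a 1.9-fold higher number from compound 1 to compound 2 (0.28 log units; within the scatter). The difference between the core of compound 1 and the core of compound 3 is not broken down here. Compound 2 and compound 3 give numbers within the scatter of each other. Within the data shown here, the step expected here is a 1.9-fold higher number from compound 3 to compound 4 (0.27 log units; within the scatter), because a 1.9-fold higher number from compound 1 to compound 2 (0.28 log units; within the scatter) is the only earlier instance of this change and was made on a different core. For compound 4 the estimated value is 1900 nM, with an expected range from 900 nM to 4000 nM.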

Compound 4, half-maximal inhibitory concentration: 2920 nM
Compound 4: middle estimate off by 1.5-fold (0.19 log units), on the low side; low and high end bracket the measured number.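

In this assay, methyl in place of hydrogen on a saturated chain carbon bound to an amine nitrogen gives a 2.9-fold higher number from compound 3 to compound 4 (0.46 log units; beyond the scatter). Set beside the earlier step, this one cannot be told apart from it, so the two cores give no sign that the change reads differently from one to the other: the same change on two cores in this assay, a 1.9-fold higher number (0.28 log units; within the scatter) from compound 1 to compound 2 and a 2.9-fold higher number (0.46 log units; beyond the scatter) from compound 3 to compound 4, 1.5-fold (0.18 log units) apart, within the scatter of two such steps. Among these compounds, with only two pairs, this shows agreement on these two cores alone; it does not show that the step is larger on the core of compound 3, or that it would hold on a further core.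

From the compounds shown here alone, how a propylamino, a dimethylamino or a free amino group in place of methylamino would read on either core remains open.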